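An Acrylamide Replaces a Sulfonamide on a Shared Core

The source may report more compounds than this note shows. Statements on the series, on what has been measured and on what is new or still open speak of the compounds shown alone.

Compound 1 `CCOC(=O)c1csc2nc(-c3ccc(NC(=O)Nc4ccccc4)cc3)cn12`: in a functional assay on HeLa cells (Homo sapiens) for cytotoxicity, read by MTT assay, with a stated time of 72 h (a lower number here means a stronger inhibitor, a higher number a weaker inhibitor), compound 1 gives > 20000 nM, a limit of the assay.
Compound 2 `CCOC(=O)c1csc2nc(-c3ccc(NC(=O)c4ccco4)cc3)cn12`: in this assay compound 2 gives > 20000 nM, again a limit.
Compound 3 `CCOC(=O)c1csc2nc(-c3ccc(NS(=O)(=O)c4ccc(C)cc4)cc3)cn12`: in this assay compound 3 gives > 20000 nM, also a limit.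

Compound 3 therefore stands at the limit of > 20000 nM in this assay, at which 3 of the 3 values shown sit, and no number places it above or below its two companions. The steps among the three are a step that the two limits leave unreadable from compound 1 to compound 2, a step that the two limits leave unreadable from compound 1 to compound 3 and a step that the two limits leave unreadable from compound 2 to compound 3, so none of them reveals how much any exchange on the nitrogen on the aromatic ring changes the read-out.

Compound 4 `C=CC(=O)Nc1ccc(-c2cn3c(C(=O)OCC)csc3n2)cc1` differs from compound 3 by vinylcarbonyl in place of (4-methylphenyl)sulfonyl on a nitrogen on an aromatic ring. For the measured compounds named here, no measured step covers a vinylcarbonyl on this nitrogen; the three known exchanges at that position all start and end at the limit, and so give no readable size in either direction.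

With nothing to anchor a shift, the step from compound 3 to compound 4 is expected to be an at least 1.3-fold lower number from compound 3 to compound 4 (0.12 log units; that floor lies within the scatter), with a real chance that the assay once more reports only a limit. Compound 4 is estimated at 15000 nM, within a range from 3000 nM to 40000 nM.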

Compound 4, half-maximal inhibitory concentration: > 20000 nM
Compound 4 gave a limit, no number; the forecaster's own chance of this, stated with the estimate: 60%; at least 1.3-fold (0.12 log units) between middle value and limit.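

In this assay compound 4 gives > 20000 nM as a limit of the assay, not a number. No new step can be read from compound 1, compound 2 or compound 3 to compound 4: the limit of > 20000 nM in this assay, at which 4 of the 4 values shown sit.

The compounds shown leave open whether any group on the nitrogen on the aromatic ring changes the read-out on the shared core, and by how much.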